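Methoxy to trifluoromethyl across ester and urea cores

A few compounds are considered here, and "the series" means these few. Any claim that something is new, unique, unknown or untested is made for them only; others in the source may bear on it.

Compound 1 `COc1ccc(C(=O)OC(CCN(C)C)c2ccc(Cl)cc2)cc1` and compound 2 `CN(C)CCC(OC(=O)c1ccc(C(F)(F)F)cc1)c1ccc(Cl)cc1` share an ester core and differ in one place: trifluoromethyl in place of methoxy on an aromatic carbon. In an assay on NIH3T3 cells with Urotensin-2 receptor (Homo sapiens) as the target (on this read-out lower numbers stand for smaller maximal responses and higher numbers for larger maximal responses), compound 1 gives 84% and compound 2 gives 47%, so that the change produces a number 37 percentage points lower from compound 1 to compound 2 (beyond the scatter).

Compound 3 `COc1ccc(NC(=O)NC(CCN(C)C)c2ccc(Cl)cc2)cc1` carries a urea core instead; the difference between the core of compound 1 and the core of compound 3 is not broken down here. In this assay compound 3 gives 195%, the highest of the three numbers, with compound 1 and compound 2 both lying beyond the scatter below it.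

Compound 4 `CN(C)CCC(NC(=O)Nc1ccc(C(F)(F)F)cc1)c1ccc(Cl)cc1` is the unmeasured counterpart of compound 3 and carries the change already seen on the ester core: trifluoromethyl in place of methoxy on an aromatic carbon. The place described for both changes is the same word for word, so the two are taken as the same change made on two different cores. A single precedent on one core is a thin base for the other, and the gap between the cores is large.

Within the data shown here, compound 4 is expected to give 155% in this assay, within a range from 100% to 210%, because compound 3 starts from 195% and the only precedent is a number 37 percentage points lower from compound 1 to compound 2 (beyond the scatter). The expected step is a number 40 percentage points lower from compound 3 to compound 4 (beyond the scatter). Among the measured compounds shown here, the range is kept wide since the cores differ and only one measured pair carries this change.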

Compound 4, largest response reached (reported as efficacy), in percent of the reference or control that the assay uses: 105%
Estimate against measurement, compound 4: 50 percentage points above; measured number inside the range.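

In this assay, trifluoromethyl in place of methoxy gives a number 90 percentage points lower from compound 3 to compound 4 (beyond the scatter), which has the same direction as on the ester core, but the size of the step does not carry over: the same change on two cores in this assay, a number 37 percentage points lower (beyond the scatter) from compound 1 to compound 2 and a number 90 percentage points lower (beyond the scatter) from compound 3 to compound 4, 53 percentage points apart, beyond the scatter of two such steps

For this one change, then, the direction held on both cores, while the size found on the core of compound 1 was no guide to the size on the core of compound 3. The two pairs do not show why the steps differ, nor whether the size follows the core itself or the starting number, since compound 1 starts at 84% and compound 3 at 195%, and two pairs give no general rule for this series.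

Open, on these data alone, is whether another group in place of methoxy on the same aromatic carbon, such as a nitrile or a single chlorine, would also give a larger step on the core of compound 3 than on the core of compound 1. Also open, as far as these compounds go, is whether the gap between the two steps would persist with a longer chain in place of the two-carbon link to the dimethylamine, or with a primary amine in place of the dimethylamine.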